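The compounds below may be only part of what the source reports. "The series", "measured", "known", "first", "only" and "open" are said of these compounds alone.

Going by the values given here, the three compounds measured so far share one core. Compound 1 `CCC(O)Cc1cn(CC(=O)NCc2ccccc2)nn1` gives 630 uM in an ADME assay on cells (spleen, Mus musculus, strain C57BL/6) for inhibition, read by flow cytometry and propidium iodide staining, with a stated time of 24 h, at 37 degrees C; a lower number here means that less compound is needed, a higher number that more compound is needed for the effect. Compound 2 `O=C(O)CCc1cn(CC(=O)NCc2ccccc2)nn1` gives 1420 uM in this assay, and compound 3 `O=C(O)CCCCc1cn(CC(=O)NCc2ccccc2)nn1` gives 1080 uM in this assay. Among the compounds with values here, compound 2 thus stands at the highest of the three numbers, but only the step of a 2.3-fold higher number from compound 1 to compound 2 (0.35 log units; beyond the scatter) lies beyond the scatter, while the step of a 1.3-fold lower number from compound 2 to compound 3 (0.12 log units; within the scatter) does not separate it from its nearest neighbour. Compound 4 `COc1cccc(-c2cn(CC(=O)NCc3ccccc3)nn2)c1` differs from compound 2 by 3-methoxyphenyl in place of 2-carboxyethyl on an aromatic carbon. Within the data shown here, the two steps that touch compound 2, a 2.3-fold higher number from compound 1 to compound 2 (0.35 log units; beyond the scatter) and a 1.3-fold lower number from compound 2 to compound 3 (0.12 log units; within the scatter), both alter a chain on a saturated carbon and stay modest or within the scatter; neither exchanges a chain for an aromatic ring, so no measured step bears closely on this change. The nearest guide is that compound 1, with its 1-hydroxypropyl, gives 630 uM, below compound 2. Compound 4 is therefore expected to move by a 2.8-fold lower number from compound 2 to compound 4 (0.45 log units; beyond the scatter), toward a lower number, with wide uncertainty. The estimate for compound 4 in this assay is 500 uM, with a range from 180 uM to 1500 uM.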

Compound 4, concentration for half-maximal effect: 840 uM
Beside the measured number, compound 4's estimate is 1.7-fold (0.23 log units) below it; the measured number falls inside the stated range.
By their numbers in this assay, from the lowest: compounds 1, 4, 3 and 2 (each within the scatter of the next, the first and the last beyond it).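

At the aromatic carbon of the five-membered aromatic ring with 3 nitrogen, an aromatic ring now takes the place of the saturated chains, and in this assay the exchange cannot be told from the scatter against any of them (a 1.7-fold lower number from compound 2 to compound 4 (0.23 log units; within the scatter); a 1.3-fold lower number from compound 3 to compound 4 (0.11 log units; within the scatter); a 1.3-fold higher number from compound 1 to compound 4 (0.12 log units; within the scatter)). This position can therefore carry 3-methoxyphenyl, which has no hydrogen-bond donor, with a number that stays within the scatter of those of the chain compounds. The data offer no explanation for how close these numbers lie.

Going by these compounds, it remains open whether a plain phenyl, or a phenyl carrying a carboxylic acid or an amine, would stay this close to compound 4. Also open, on these data alone, is whether a change elsewhere on the shared core would move the number further than any change at this position has.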